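Expected Inhibition After a Halogen Swap on the Benzyl Group

The compounds below may be only part of what the source reports. "The series", "measured", "known", "first", "only" and "open" are said of these compounds alone.

Compound 1, `CC1=C(C(=O)Nc2ccc([N+](=O)[O-])cc2)C(c2cccc([N+](=O)[O-])c2)N=C(SCc2ccccc2)N1`, in a functional assay on the whole organism (artery, strain albino) with Rattus norvegicus as the target, with a stated time of 180 min, at a dose of 10 mg/kg by the oral route; a higher number here means more inhibition at the dose given (going by the name of the read-out), a lower number less inhibition: 16.5%
Compound 2, `CC1=C(C(=O)Nc2ccc([N+](=O)[O-])cc2)C(c2cccc([N+](=O)[O-])c2)N=C(SCc2cccc(Cl)c2)N1`: 14.9%

Compound 2 carries the smaller of the two numbers, yet the step of a number 1.6 percentage points lower from compound 1 to compound 2 (within the scatter) lies within the scatter, so compound 2 and compound 1 cannot be separated by these measurements.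

Compound 3, `CC1=C(C(=O)Nc2ccc([N+](=O)[O-])cc2)C(c2cccc([N+](=O)[O-])c2)N=C(SCc2ccc(F)cc2)N1`, is not yet measured. It differs from compound 2 in one place: 4-fluorophenyl in place of 3-chlorophenyl on a saturated chain carbon bound to a sulfur. Within the data shown here, the only measured step that bears on this ring, a number 1.6 percentage points lower from compound 1 to compound 2 (within the scatter), was within the scatter, which suggests that changing the halogen on the benzyl ring leaves the read-out largely unchanged. Among the measured compounds shown here, no measured step shows a fluoro on this ring, so the expectation rests on that one step alone. Compound 3 is therefore expected to show no step beyond the scatter, a number 0.6 percentage points higher from compound 2 to compound 3 (within the scatter). The estimate for compound 3 is 15.5%, with a range from 5% to 26%.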

Compound 3, a percentage reported as inhibition, in the whole organism at one dose (the size of the read-out at that dose, not a potency): 17.5%
For compound 3 the middle estimate is 2 percentage points below the measured one; the measured number falls inside the stated range.
By their numbers in this assay, from the lowest: compounds 2, 1 and 3 (each within the scatter of the next).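

The 4-fluorobenzyl group on the sulfur adds a second halogen to this ring in this assay, and the number stays put against both neighbours (a number 2.6 percentage points higher from compound 2 to compound 3 (within the scatter); a number 1 percentage points higher from compound 1 to compound 3 (within the scatter)). The benzyl, 3-chlorobenzyl and 4-fluorobenzyl compounds therefore cannot be separated by this read-out, so neither swapping 3-chlorophenyl for 4-fluorophenyl nor adding either halogen to the bare ring produces a step beyond the scatter. No measurement at hand accounts for this flat result.

The compounds shown leave open whether a different kind of group on this ring, such as an amine or a carboxylic acid, would move the inhibition beyond the scatter. They also leave open what a longer chain in place of the benzyl group on the sulfur would do.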